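This account rests on a few compounds, and the source may have more. Where it says the series, first, only, none or still open, it means among the compounds named here.

Compound 1 `COc1cc(-c2cc(/C=C/C(=O)c3ccc(N)cc3)[nH]n2)cc(OC)c1OC`, compound 2 `COc1ccc(C(=O)/C=C/c2cc(-c3cc(OC)c(OC)c(OC)c3)n[nH]2)cc1OC` and compound 3 `COc1ccc(C(=O)/C=C/c2cc(-c3cc(OC)c(OC)c(OC)c3)n[nH]2)cc1` were all tested in a functional assay on SF-268 cells (Homo sapiens) for cytotoxicity, read by sulforhodamine B assay, with a stated time of 48 h, tested at 1 uM; on this read-out higher numbers stand for a weaker effect at the one concentration tested and lower numbers for a stronger effect. In this assay compound 1 gives 81%, compound 2 gives 89% and compound 3 gives 87%. Compound 3 arises from compound 2 by a single change, (hydrogen in place of methoxy on an aromatic carbon), which made a step of a number 2 percentage points lower from compound 2 to compound 3 (within the scatter). Compound 4 `COc1ccc(-c2cc(/C=C/C(=O)c3ccc(N)cc3)[nH]n2)cc1OC` arises from compound 1 by a change of the same kind, (hydrogen in place of methoxy on an aromatic carbon). The cores of compound 1 and compound 2 differ by 4-aminophenyl in place of 3,4-dimethoxyphenyl on a carbonyl carbon. Around the place of the change, compound 1 additionally has the carbon meta to a methoxy group (2 heavy atoms), which compound 2 lacks. Compound 4 is expected to show a step of a number 2 percentage points lower from compound 1 to compound 4 (within the scatter) because the earlier step of a number 2 percentage points lower from compound 2 to compound 3 (within the scatter) stayed within the scatter. Compound 4 is therefore estimated at 79% in this assay.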

Compound 4, a percentage reported as activity, at one concentration (the size of the read-out at that concentration, not a potency): 88%
Beside the measured number, compound 4's estimate is 9 percentage points below it; the range from low to high includes it.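

Putting hydrogen in place of methoxy on an aromatic carbon of the core of compound 1 gives a step of a number 7 percentage points higher from compound 1 to compound 4 (within the scatter) in this assay. Set beside the same change on the other core, the two steps do not differ: the same change on two cores in this assay, a number 2 percentage points lower (within the scatter) from compound 2 to compound 3 and a number 7 percentage points higher (within the scatter) from compound 1 to compound 4, 9 percentage points apart, within the scatter of two such steps. Nothing here speaks against the change carrying over between these two cores, yet both steps lie within the scatter, so this does not show that a change with a clear effect on one core would repeat on the other.

The compounds shown leave open what other groups on this ring, such as a hydroxy group or a chlorine atom, would do. They also leave open how these compounds compare at other concentrations.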